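This account rests on a few compounds, and the source may have more. Where it says the series, first, only, none or still open, it means among the compounds named here.

Compound 1 `Cc1cn([C@@H]2O[C@H](CO)[C@@]3(OS(=O)(=O)C=C3NC(=O)NC(=O)c3ccccc3)[C@H]2O[Si](C)(C)C(C)(C)C)c(=O)n(C)c1=O` and compound 2 `Cc1cn([C@@H]2O[C@H](CO[Si](C)(C)C(C)(C)C)[C@@]3(OS(=O)(=O)C=C3NC(=O)NC(=O)c3ccccc3)[C@H]2O)c(=O)n(C)c1=O` are built from the same atoms joined differently; the difference between the two cores is not broken down here. In an ADME assay on HEL cells (Homo sapiens) for cytotoxicity, with a stated time of 3 days (a lower number here means that less compound is tolerated, a higher number that more compound is tolerated), compound 1 gives 16000 nM. In this assay compound 2 gives 22000 nM, a value that sits within the usual scatter of the number for compound 1, so no order between the two is claimed.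

Compound 3 `Cc1cn([C@@H]2O[C@H](CO[Si](C)(C)C(C)(C)C(C)C)[C@@]3(OS(=O)(=O)C=C3NC(=O)NC(=O)c3ccccc3)[C@H]2O[Si](C)(C)C(C)(C)C)c(=O)n(C)c1=O` differs from compound 1 by a group of 9 heavy atoms (8 carbon, 1 silicon; no ring) in place of a hydrogen atom, on an oxygen on a saturated carbon. For compound 3 in this assay only a limit is recorded, > 50000 nM. The step of an at least 3.1-fold higher number from compound 1 to compound 3 (0.49 log units; beyond the scatter) therefore rests on the limit of > 50000 nM in this assay, at which 1 of the 3 values shown sits, and gives a floor for the change rather than its full size.

Compound 4 `Cc1cn([C@@H]2O[C@H](CO[Si](C)(C)C(C)(C)C)[C@@]3(OS(=O)(=O)C=C3NC(=O)NC(=O)c3ccccc3)[C@H]2O[Si](C)(C)C(C)(C)C(C)C)c(=O)n(C)c1=O` has not yet been measured. Relative to compound 2 it carries a group of 9 heavy atoms (8 carbon, 1 silicon; no ring) in place of a hydrogen atom, on an oxygen on a saturated carbon. The surroundings of the two places are not identical: for compound 3 the oxygen sits on a saturated carbon whose other neighbour is a saturated chain carbon, whereas for compound 4 that carbon's other neighbour is a saturated ring carbon, so the change is of the same kind as the earlier one, not the same.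

Within the data shown here, for compound 4 in this assay the expected step is a 3.0-fold higher number from compound 2 to compound 4 (0.47 log units; beyond the scatter), set beside the measured at least 3.1-fold higher number from compound 1 to compound 3 (0.49 log units; beyond the scatter), since the one measured instance of this kind of change ran into the limit. The expected number for compound 4 in this assay is 65000 nM, with a range from 28000 nM to 160000 nM, and a fair chance that only a limit is returned.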

Compound 4, half-maximal cytotoxic concentration: >= 100000 nM
Compound 4: only a limit was reported (the forecaster's own chance of this, stated with the estimate: 60%); middle value at least 1.5-fold (0.18 log units) from the limit.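

In this assay, the group of 9 heavy atoms (8 carbon, 1 silicon; no ring) in place of a hydrogen atom on an oxygen on a saturated carbon again gives a rise beyond the scatter, an at least 4.5-fold higher number from compound 2 to compound 4 (0.65 log units; beyond the scatter), so the direction seen on the core of compound 1 also holds on the core of compound 2, though the oxygen's surroundings differ. This agreement in direction does not establish that the change has the same size on both cores, and no transferable size can be stated for the series from these two instances: the same change on two cores in this assay, an at least 3.1-fold higher number (0.49 log units; beyond the scatter) from compound 1 to compound 3 and an at least 4.5-fold higher number (0.65 log units; beyond the scatter) from compound 2 to compound 4; the limit leaves it open whether they differ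

Compound 4 gives a limit and not a number, so its step is a floor and the true tolerated concentration remains unknown: the limit of >= 100000 nM in this assay, at which 1 of the 4 values shown sits.

The compounds shown do not tell whether the rise in this assay follows from the silicon in this group or would also appear with a carbon-only group, such as a longer alkyl chain, on the same oxygen. Also open, from the compounds shown here alone, is whether a group with a basic nitrogen, such as an amine, placed on that oxygen would move the number in the same direction on either core.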